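Side-chain replacement on compound 1: expected potency in cells

This account rests on a few compounds, and the source may have more. Where it says the series, first, only, none or still open, it means among the compounds named here.

Measured so far:
compound 1 `CC1=C(N2CC2)C(=O)C(C(C)COC(N)=O)=C(N2CC2)C1=O` — 5.31
compound 2 `CCOC(COC(N)=O)C1=C(N2CC2)C(=O)C(C)=C(N2CC2)C1=O` — 4.62

In a functional assay on L1210 cells (Mus musculus), with a stated time of 1 days (on this read-out lower numbers stand for lower potency and higher numbers for higher potency (the scale is a negative logarithm)), compound 1 stands highest of the two numbers; compound 2 is the nearest, and a number 0.69 log units lower from compound 1 to compound 2 (beyond the scatter), a change of ethoxy in place of methyl on a saturated chain carbon bound to a double-bonded ring carbon and a saturated chain carbon.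

Compound 3 `COCCC1=C(N2CC2)C(=O)C(C)=C(N2CC2)C1=O` is not yet measured. It differs from compound 1 thus: a group of 4 heavy atoms (3 carbon, 1 oxygen; no ring) in place of a group of 7 heavy atoms (4 carbon, 1 nitrogen, 2 oxygen; no ring), on a double-bonded ring carbon. Among the compounds with values here, the one measured step touches the same side chain but keeps the carbamate that compound 3 loses, so it bears on the new step only loosely. It showed that a change on this chain can lower the read-out by a modest amount. A similar or somewhat smaller fall is expected, with wide uncertainty. Compound 3 is therefore estimated at 4.9, range 4.2 to 5.6, an expected a number 0.41 log units lower from compound 1 to compound 3 (beyond the scatter).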

Compound 3, logarithm of the reciprocal of the active concentration, log(1/C): 5.12
Beside the measured number, compound 3's estimate is 0.22 log units below it; the range from low to high includes it.
By their numbers in this assay, from the lowest: compound 2; then compounds 3 and 1 (each within the scatter of the next).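

In this assay, the step to 2-methoxyethyl gives a number 0.19 log units lower from compound 1 to compound 3 (within the scatter). The whole group of 7 heavy atoms on the double-bonded ring carbon, including its carbamate and its hydrogen-bond donor, can therefore be exchanged at this position without a change beyond the scatter, so the carbamate is not needed for compound 3 to reach a value level with that of compound 1. No supporting data bear on why this exchange is tolerated.

On these data alone, whether a longer chain, a primary amine or a carboxylic acid in place of 2-methoxyethyl would keep the read-out at this level remains open. Also open, as far as these compounds go, is whether an ethoxy branch on the 2-methoxyethyl chain, without the carbamate, would bring a fall like that in a number 0.69 log units lower from compound 1 to compound 2 (beyond the scatter).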